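This account rests on a few compounds, and the source may have more. Where it says the series, first, only, none or still open, it means among the compounds named here.

The measured compounds in an ADME assay on a cell-free system (plasma, Homo sapiens) for metabolic stability, with Plasma (Rattus norvegicus) as the target, read by HPLC, at pH 7.4; a lower number here means that the compound disappears faster, a higher number that the compound lasts longer:
compound 1 `CC(=O)Oc1ccccc1C(=O)O[C@H]1CO[C@H]2[C@@H]1OC[C@H]2OC(=O)c1ccccc1O` gives 0.0825 h
compound 2 `CC(=O)Oc1ccccc1C(=O)O[C@H]1CO[C@H]2[C@@H]1OC[C@H]2OC(=O)c1ccccc1` gives 0.055 h
compound 3 `CC(=O)Oc1ccccc1C(=O)O[C@H]1CO[C@H]2[C@@H]1OC[C@H]2OC(=O)c1ccncc1` gives 0.0617 h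

Compound 2 holds the lowest of these three numbers, but the gaps to its neighbours, a 1.1-fold higher number from compound 2 to compound 3 (0.05 log units; within the scatter) and a 1.5-fold lower number from compound 1 to compound 2 (0.18 log units; within the scatter), both lie within the scatter, so the three stand level. Compound 4 `CC(=O)Oc1ccccc1C(=O)O[C@H]1CO[C@H]2[C@@H]1OC[C@H]2OC(=O)c1ccc(CO[N+](=O)[O-])cc1` has not been measured; it differs from compound 2 by (nitrooxy)methyl in place of hydrogen on an aromatic carbon. The two measured steps that bear on it are changes on the same ring of the same ester, and neither moved the number beyond the scatter. The new group is bulkier than either of those changes, yet nothing measured points to a direction, so compound 4 is expected to show no step beyond the scatter, a 1.1-fold higher number from compound 2 to compound 4 (0.04 log units; within the scatter). Compound 4 is therefore estimated at 0.06 h, within 0.03 h to 0.12 h.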

Compound 4, half-life: 0.1 h
Compound 4: middle estimate off by 1.7-fold (0.22 log units), on the low side; measured number inside the range.
By their numbers in this assay, from the lowest: compounds 2, 3, 1 and 4 (each within the scatter of the next).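

In this assay the aromatic carbon para to a large group takes (nitrooxy)methyl with a 1.8-fold higher number from compound 2 to compound 4 (0.26 log units; within the scatter) and no step beyond the scatter, so a group of 5 heavy atoms is tolerated here on this read-out. The other two comparisons, a 1.6-fold higher number from compound 3 to compound 4 (0.21 log units; within the scatter) and a 1.2-fold higher number from compound 1 to compound 4 (0.08 log units; within the scatter), also stay within the scatter, which leaves all four compounds level. Nothing shown here explains these numbers.

The compounds shown leave open whether any group at this place, such as an amine, a carboxylic acid or a longer chain bearing the nitrooxy group, would move the half-life beyond the scatter.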